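Swapping the oxime end group on compound 1

The source may report more compounds than this note shows. Statements on the series, on what has been measured and on what is new or still open speak of the compounds shown alone.

Measured compounds:
Compound 1, `CC(=O)/C(=N\O)c1ccc(Sc2cc(F)cc(C3CCOCC3)c2)cc1`: 850 nM
Compound 2, `COC1(c2cc(F)cc(Sc3ccc4c(c3)OCC/C4=N\OCC#N)c2)CCOCC1`: 40 nM
Compound 3, `C/C(=N\O)c1ccccc1Sc1cc(F)cc(C2CCOCC2)c1`: > 10000 nM

Of the compounds shown here, three have been tested in a functional assay (blood) for inhibition, with Homo sapiens as the target; a lower number here means a stronger inhibitor, a higher number a weaker inhibitor. Compound 1 gives 850 nM in this assay. Compound 2 gives 40 nM, a much lower number, and compound 1 therefore stands at the highest of the two measured numbers. Compound 3 is reported only as a limit of this assay, > 10000 nM, so no number exists for it; this is the limit of > 10000 nM in this assay, at which 1 of the 3 values shown sits.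

The next step goes from compound 1 to compound 4, `C/C(=N\OC(=O)C(C)(C)C)c1ccc(Sc2cc(F)cc(C3CCOCC3)c2)cc1`, which has not yet been measured. The change is a group of 10 heavy atoms (7 carbon, 1 nitrogen, 2 oxygen; no ring) in place of a group of 6 heavy atoms (3 carbon, 1 nitrogen, 2 oxygen; no ring), on an aromatic carbon. In words, the group that leaves carries a hydrogen-bond donor and the group that enters carries none, while the count of acceptors stays the same.

Within the data shown here, no measured pair differs in just this one place, so the expectation rests on compound 1 alone. A small step is expected in this assay, toward a somewhat higher number, but not clearly beyond the scatter, with the step from compound 1 to compound 4 estimated as a 1.8-fold higher number from compound 1 to compound 4 (0.25 log units; within the scatter). Compound 4 is expected to give about 1500 nM, between 300 nM and 8000 nM.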

Compound 4, half-maximal inhibitory concentration: 40 nM
For compound 4 the middle estimate is 38-fold (1.57 log units) above the measured one; the measured number lies below the stated range.
By their numbers in this assay, from the lowest: compounds 2 and 4 (each within the scatter of the next); then compound 1. At a limit, above all of these: compound 3.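

In this assay, this position, on an aromatic carbon and para to a large group, proves far more sensitive to its substituent than compound 1 alone could reveal: the change gives a 21-fold lower number from compound 1 to compound 4 (1.33 log units; beyond the scatter). The group that enters has 10 heavy atoms against 6 for the group that leaves, and it has 0 hydrogen-bond donors against 1, so neither the smaller group nor its hydrogen-bond donor is required for a low number in this series. Size and donor count change together in this single step, and nothing shown gives a cause for the drop.

The compounds shown do not separate these two changes, so it remains open whether a small group without a donor, such as a methyl ether, would give a similar number to a large one. As far as these compounds go, it is also open how far this position can be pushed, for example with a longer chain, an amine or a carboxylic acid in place of the group in compound 4.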